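Swapping a carbamoyl for a tosyl on the ring nitrogen

This account rests on a few compounds, and the source may have more. Where it says the series, first, only, none or still open, it means among the compounds named here.

Among the measured compounds shown here, compound 1 `C=CCNC(=O)n1c(-c2ccc(OC)cc2)cc(=O)c2c(OC)cc(OC)cc21` has the only plain number here: in an ADME assay on BJ cells (Homo sapiens) for antiproliferative activity, with a stated time of 72 h (on this read-out higher numbers stand for an effect only at larger amounts of compound and lower numbers for an effect already at smaller amounts), compound 1 gives 74000 nM. Compound 2 `COc1ccc(-c2[nH]c3cc(OC)cc(OC)c3c(=O)c2I)cc1` reaches only a limit of the assay, and in this assay compound 2 gives > 86200 nM. Compound 3 `COc1ccc(-c2cc(=O)c3c(OC)cc(OC)cc3n2S(=O)(=O)c2ccc(Cl)cc2)cc1` likewise reaches only a limit, and in this assay compound 3 gives > 34400 nM. The step from compound 1 to compound 3 in this assay is a step that the limit leaves unreadable from compound 1 to compound 3. Compound 4 `COc1ccc(-c2cc(=O)c3c(OC)cc(OC)cc3n2S(=O)(=O)c2ccc(C)cc2)cc1` differs from compound 1 by (4-methylphenyl)sulfonyl in place of allylcarbamoyl on an aromatic nitrogen. This change resembles the step to compound 3 (the limit of > 34400 nM in this assay, at which 1 of the 3 values shown sits), whose limit leaves its size unreadable, so no shift beyond the scatter can be expected. Compound 4 is therefore expected to give about 80000 nM in this assay, within 35000 nM to 200000 nM. The expected step is a 1.1-fold higher number from compound 1 to compound 4 (0.03 log units; within the scatter).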

Compound 4, half-maximal effective concentration: > 44800 nM
Compound 4: a limit, no number; the forecaster's own chance of this, stated with the estimate: 60%; the middle value is on the limit's open side.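

Compound 4 gives only a limit, and the steps to it from compound 1 and from compound 3 cannot be read. The compounds shown leave open whether either sulfonyl group truly shifts the number relative to allylcarbamoyl, and whether methyl and chloro differ.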